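The source may hold more compounds than are shown below. What is called first, only, known or untested is meant among the compounds shown, and "the series" means these compounds.

Measured compounds:
- compound 3 `CCOc1ccc2c(=O)cc(C(C)Br)oc2c1CBr`: in a functional assay on A549 cells (Homo sapiens) for antiproliferative activity, read by sulforhodamine B assay, with a stated time of 72 h (on this read-out lower numbers stand for stronger inhibition of growth and higher numbers for weaker inhibition of growth), compound 3 gives 19800 nM.
- compound 2 `COc1ccc2c(=O)cc(C(C)Br)oc2c1CBr`: in this assay compound 2 gives > 26500 nM, which is a limit of the assay rather than a number.
- compound 1 `CCc1cc(=O)c2ccc(OC(C)C)c(CBr)c2o1`: in this assay compound 1 gives > 30700 nM, also a limit of the assay.

Compound 3 is therefore the only one of the three with a true number; the other two sit at limits, namely the limit of > 26500 nM in this assay, at which 1 of the 3 values shown sits, and (the limit of > 30700 nM in this assay, at which 1 of the 3 values shown sits). Compound 4 `CC(C)Oc1ccc2c(=O)cc(C(C)Br)oc2c1CBr` differs from compound 3 by methyl in place of hydrogen on a saturated chain carbon bound to an oxygen on an aromatic ring and a saturated chain carbon. Among the compounds with values here, the only measured step of the same kind is an at least 1.3-fold lower number from compound 2 to compound 3 (0.12 log units; that floor lies within the scatter), where a methyl group was added to the same oxygen-bound chain carbon, and that step lies within the scatter of the method. Compound 1 also carries the isopropoxy group of compound 4, but it differs from compound 4 in more than one place and sits at a limit. A second methyl on that chain is thus expected to change the reading little, if at all. Compound 4 is expected to give about 17000 nM in this assay, within 7000 nM to 40000 nM. The expected step of a 1.2-fold lower number from compound 3 to compound 4 (0.07 log units; within the scatter) stays within the usual scatter.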

Compound 4, concentration for 50% growth inhibition: 12800 nM
Compound 4: the middle estimate sits 1.3-fold (0.12 log units) above what was measured, and the stated range covers the measured number.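

Adding this methyl, which turns ethoxy into isopropoxy, is on its own too small a change to separate from repeat error in this assay (a 1.5-fold lower number from compound 3 to compound 4 (0.19 log units; within the scatter)), just as the earlier step at this carbon was. The new result shows that the full change on that oxygen does register, since the step from methoxy to isopropoxy clears the scatter (an at least 2.0-fold lower number from compound 2 to compound 4 (0.31 log units; beyond the scatter)), and the isopropoxy group alone is not enough, since bromo in place of hydrogen on the saturated chain carbon at the other site also gives a step beyond the scatter (an at least 2.3-fold lower number from compound 1 to compound 4 (0.37 log units; beyond the scatter)). Going by these compounds, each of these two larger steps starts from a limit of the assay, so each gives only a floor and its true size stays unknown.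

Still open, on these data alone, is whether a longer chain such as butyl on that oxygen, a ring such as cyclopentyl, or an amine carried on that chain would lower the number further or raise it. Also open, as far as these compounds go, is whether the bromo on the side chain could give way to chloro or hydroxyl without losing the effect seen in compound 4 (12800 nM).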